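Urea versus amide linkers in a pyrazole growth-inhibitor series

A few compounds are considered here, and "the series" means these few. Any claim that something is new, unique, unknown or untested is made for them only; others in the source may bear on it.

Measured so far:
- compound 1, `O=C(Nc1cccc(-n2cc(-c3ccncc3)c(-c3ccc(Cl)c(O)c3)n2)c1)Nc1cccc(C(F)(F)F)c1`: > 32500 nM
- compound 2, `COc1cc(-c2nn(-c3cccc(NC(=O)Nc4cc(C(F)(F)F)cc(C(F)(F)F)c4)c3)cc2-c2ccncc2)ccc1Cl`: 1640 nM
- compound 3, `COc1cc(-c2nn(-c3cccc(NC(=O)c4cccc(C(F)(F)F)c4)c3)cc2-c2ccncc2)ccc1Cl`: > 50000 nM

In a functional assay on HCT-15 cells (Homo sapiens) for inhibition, read by sulforhodamine B assay, with a stated time of 48 h (a higher number here means a weaker inhibitor of growth, a lower number a stronger inhibitor of growth), compound 3 gives only a limit, > 50000 nM, with no number reached (the limit of > 50000 nM in this assay, at which 1 of the 3 values shown sits). Compound 1 likewise returns only a limit (the limit of > 32500 nM in this assay, at which 1 of the 3 values shown sits). Going by the values given here, compound 2, the one urea on the methoxy core, is the sole compound of the three with a measured number, 1640 nM.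

Compound 4, `COc1cc(-c2nn(-c3cccc(NC(=O)Nc4ccc(Cl)c(Cl)c4)c3)cc2-c2ccncc2)ccc1Cl`, differs from compound 3 by (3,4-dichlorophenyl)amino in place of 3-(trifluoromethyl)phenyl on a carbonyl carbon. The change turns the amide of compound 3 into a urea, as in compound 2. The step from compound 3 to compound 4 is expected to run toward stronger growth inhibition, beyond the scatter, an at least 16-fold lower number from compound 3 to compound 4 (1.22 log units; beyond the scatter), because compound 2 gives 1640 nM. Compound 4 is therefore estimated at 3000 nM, between 800 nM and 15000 nM.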

Compound 4, concentration for total growth inhibition: > 50000 nM
Compound 4 gave a limit, no number; the forecaster's own chance of this, stated with the estimate: 20%; middle value at least 16-fold (1.22 log units) from the limit.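

Compound 4 gives only a limit, > 50000 nM. Compound 3 is also a limit, so the step between compound 3 and compound 4 cannot be read. Left open is how the urea's aryl group governs growth inhibition, since compound 2 reaches a number and compound 4 does not.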